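Swapping halogens on a pyrazine-dione pair of aryl groups

The compounds below may be only part of what the source reports. "The series", "measured", "known", "first", "only" and "open" are said of these compounds alone.

Three compounds share one core and differ only in the aryl groups hanging from it. Compound 1 `C=CCn1c(=O)/c(=C\c2ccc(Cl)c(Cl)c2)[nH]c(=O)/c1=C\c1ccccc1` was tested in a functional assay on K562 cells (Homo sapiens) for cytotoxicity, read by CCK-8 assay, with a stated time of 72 h (a lower number here means a stronger inhibitor, a higher number a weaker inhibitor), and returned "not active" (no number reported). Compound 3 `COc1ccccc1/C=c1/[nH]c(=O)/c(=C\c2cccc(Cl)c2Cl)[nH]c1=O` likewise gave "not active" (no number reported) in this assay. For the measured compounds named here, compound 2 `C=CCn1c(=O)/c(=C\c2cc(F)ccc2C)[nH]c(=O)/c1=C\c1ccccc1OC` is the only member with a numerical result, giving 1800 nM in this assay, so it stands alone as the reference point here, with nothing to rank it against.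

Compound 4 `C=CCn1c(=O)/c(=C\c2cc(Br)ccc2F)[nH]c(=O)/c1=C\c1ccccc1OC` has not yet been measured. It differs from compound 2 by 5-bromo-2-fluorophenyl in place of 5-fluoro-2-methylphenyl on a double-bonded chain carbon bound to an aromatic carbon. Going by the values given here, no measured pair shows the effect of such an exchange, so nothing here tells how large a step it produces. The two groups are counted as the same size and carry the same number of donors and acceptors, and the core and the other aryl group are unchanged, so the expected step of a 1.1-fold higher number from compound 2 to compound 4 (0.05 log units; within the scatter) is none beyond the usual scatter. Compound 4 is therefore expected to give about 2000 nM in this assay, with a plausible range from 700 nM to 6000 nM.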

Compound 4, half-maximal inhibitory concentration: 5100 nM
The estimate for compound 4 lay 2.6-fold (0.41 log units) below the measured number; measured number inside the range.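

For the compounds shown here, the first readable step at this position is a 2.8-fold higher number from compound 2 to compound 4 (0.45 log units; beyond the scatter) in this assay, so exchanging 5-fluoro-2-methylphenyl for 5-bromo-2-fluorophenyl gives a modestly weaker inhibitor that still returns a number. Equal heavy-atom counts and equal donor and acceptor counts therefore do not make these two groups interchangeable on a double-bonded chain carbon bound to an aromatic carbon. No measurement is available that explains this difference.

A single step cannot show whether gaining the bromine or losing the methyl accounts for the higher number, as both changes arrive together. As far as these compounds go, how a phenyl group carrying an amine or a carboxylic acid would behave at this place also remains open.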